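Amide side-chain changes on the shared core

This account rests on a few compounds, and the source may have more. Where it says the series, first, only, none or still open, it means among the compounds named here.

Measured so far:
- compound 1 `CCn1c(C(=O)N[C@H](C)CO)ccc1C(CC)(CC)c1ccc(OCS(=O)(=O)c2ccccc2)c(C)c1`, in a functional assay on PC-3 cells (Homo sapiens) for antiproliferative activity, read by MTT assay, with a stated time of 24 h (a lower number here means a stronger inhibitor, a higher number a weaker inhibitor), gives 7790 nM
- compound 2 `CCn1c(C(=O)N[C@@H](CO)CCO)ccc1C(CC)(CC)c1ccc(OCS(=O)(=O)c2ccccc2)c(C)c1`, in this assay gives 14100 nM

Compound 2 carries the highest of the two numbers in this assay. Its nearest neighbour is compound 1, and the step of a 1.8-fold higher number from compound 1 to compound 2 (0.26 log units; within the scatter) lies within the scatter, so the two values cannot be ordered on these data.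

Compound 3 `CCn1c(C(=O)NCCC(=O)O)ccc1C(CC)(CC)c1ccc(OCS(=O)(=O)c2ccccc2)c(C)c1` has not yet been measured in this assay. It differs from compound 2 at the same amide-type nitrogen that was varied before: 2-carboxyethyl in place of 3-hydroxy-1-(hydroxymethyl)propyl on an amide-type nitrogen

Within the data shown here, the only measured step that bears on this position is the one from compound 1 to compound 2, which exchanged the group on that amide-type nitrogen and gave a 1.8-fold higher number from compound 1 to compound 2 (0.26 log units; within the scatter), within the scatter. Nothing measured covers the carboxyethyl group itself, so no direction can be read from the series for this change. On that basis the expectation for compound 3 is a step of a 1.2-fold lower number from compound 2 to compound 3 (0.07 log units; within the scatter) from compound 2, not beyond the scatter, and compound 3 is estimated at 12000 nM, within a range from 5000 nM to 30000 nM.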

Compound 3, half-maximal inhibitory concentration: 14400 nM
The estimate for compound 3 lay 1.2-fold (0.08 log units) below the measured number, within the range that was stated.
By their numbers in this assay, from the lowest: compounds 1, 2 and 3 (each within the scatter of the next).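

Notes on the amide-type nitrogen: in this assay, replacing 3-hydroxy-1-(hydroxymethyl)propyl with 2-carboxyethyl gives a 1.0-fold higher number from compound 2 to compound 3 (0.01 log units; within the scatter), so this exchange, which removes the defined stereocentre and brings in a double bond outside aromatic rings, leaves no readable difference. Replacing 1-(hydroxymethyl)ethyl with 2-carboxyethyl gives a 1.8-fold higher number from compound 1 to compound 3 (0.27 log units; within the scatter), so all three groups on this nitrogen now lie within the scatter of one another and cannot be ordered, a finding that holds for these three compounds only. No supporting data bear on this result, and the numbers alone stand as the record for this position.

The compounds shown cover only open-chain groups carrying hydroxyl or carboxyl ends, so it remains open whether an amine such as 2-aminoethyl, a longer chain such as 5-carboxypentyl, or a ring such as benzyl on this nitrogen would move the number beyond the scatter. Also open is whether the amide hydrogen itself matters, since a second alkyl group such as methyl on this nitrogen does not appear among these compounds.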